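The source may hold more compounds than are shown below. What is called first, only, known or untested is meant among the compounds shown, and "the series" means these compounds.

In an ADME assay on HEK-293T cells (Homo sapiens) for cytotoxicity, read by CCK-8 assay, with a stated time of 24 h (on this read-out higher numbers stand for lower toxicity in this test and lower numbers for higher toxicity in this test), compound 1 `O=C(CSc1c[nH]c2ccccc12)NCc1ccccc1` gives > 100000 nM, which is a limit of the assay and not a number. Compound 2 `CN(Cc1ccccc1)C(=O)CSc1c[nH]c2ccccc12`, with methyl in place of hydrogen on an amide-type nitrogen, gives > 100000 nM, which is also a limit. Compound 2 therefore has no exact position on the scale, and the evidence so far comes down to the limit of > 100000 nM in this assay, at which 2 of the 2 values shown sit. For the measured compounds named here, the only measured step is a step that the two limits leave unreadable from compound 1 to compound 2, so it offers no size to carry forward.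

Compound 3 `CN(Cc1ccccc1)C(=O)CSc1c[nH]c2cccc(Br)c12` differs from compound 2 by one change: bromo in place of hydrogen on an aromatic carbon. In words, this is bromo in place of hydrogen on an aromatic carbon. Going by the values given here, no measured step involves this change, so the data give no direct guide to its size. With compound 2 at > 100000 nM, a limit, no clear move in either direction is expected in this assay. The expected size is an at least 1.1-fold lower number from compound 2 to compound 3 (0.04 log units; that floor lies within the scatter). For compound 3, the estimated value is 90000 nM, with an expected range from 30000 nM to 150000 nM.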

Compound 3, half-maximal cytotoxic concentration: 25100 nM
Beside the measured number, compound 3's estimate is 3.6-fold (0.55 log units) above it, outside the stated range (below it).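

In this assay, bromo in place of hydrogen on an aromatic carbon, ortho to a fused ring and meta to a fused ring, gives the first readable step among these compounds: an at least 3.9-fold lower number from compound 2 to compound 3 (0.60 log units; beyond the scatter). On this read-out, a lower number stands for higher toxicity in this test, so this change shows that the place on the six-membered aromatic ring can affect the result, something the earlier step could not show, as the two limits left it unreadable. The new step has a minimum size but no exact size, since its starting point, compound 2, is a limit and not a number: the limit of > 100000 nM in this assay, at which 2 of the 3 values shown sit.

The compounds shown leave open whether chloro, methoxy or an amine at this same place would lower the number as bromo does, and whether bromo on another carbon of this ring would do the same. They also leave open whether keeping the amide hydrogen, as in compound 1, would change the result with bromo present, as bromo appears here only together with the methyl on the amide-type nitrogen.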